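This account rests on a few compounds, and the source may have more. Where it says the series, first, only, none or still open, it means among the compounds named here.

Two cores are in play. Compound 1 `COc1cc(C#N)ccc1OCc1nnc(-c2ccc(C)cc2)o1` carries a 4-methylphenyl on its core; in a functional assay on MCF7 cells (Homo sapiens) for cytotoxicity, read by MTT assay, with a stated time of 48 h (a higher number here means a weaker inhibitor, a lower number a stronger inhibitor), compound 1 gives 27100 nM. Compound 2 `COc1cc(C#N)ccc1OCc1nnc(-c2ccc(F)cc2)o1` differs from compound 1 by fluoro in place of methyl on an aromatic carbon; in this assay compound 2 gives 10300 nM. The step of a 2.6-fold lower number from compound 1 to compound 2 (0.42 log units; beyond the scatter) is the only measured example of this change among the compounds shown.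

Compound 3 `Cc1ccc(-c2nnc(COc3ccc(-c4nnco4)cc3)o2)cc1` is built on a second core; the difference between the two cores is not broken down here. In this assay compound 3 gives > 50000 nM, which is a limit of the assay and not a number. The record of this kind is the limit of > 50000 nM in this assay, at which 1 of the 3 values shown sits.

Compound 4 `Fc1ccc(-c2nnc(COc3ccc(-c4nnco4)cc3)o2)cc1` is not yet measured. It differs from compound 3 by fluoro in place of methyl on an aromatic carbon, the same change that separates compound 1 from compound 2, made at a place described in the same words. Compound 4 is expected to show an at least 1.2-fold lower number from compound 3 to compound 4 (0.09 log units; that floor lies within the scatter) in this assay. Among the measured compounds shown here, that expectation rests on compound 2, whose step a 2.6-fold lower number from compound 1 to compound 2 (0.42 log units; beyond the scatter) is the one measured instance of the change, and on compound 3, which gives only a limit, so the starting point is itself open. Compound 4 is therefore estimated at 40000 nM in this assay, within 12000 nM to 130000 nM, with a fair chance that only a limit is reported again.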

Compound 4, half-maximal inhibitory concentration: 35600 nM
Beside the measured number, compound 4's estimate is 1.1-fold (0.05 log units) above it; low and high end bracket the measured number.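

Carried to the second core, the change from 4-methylphenyl to 4-fluorophenyl gives an at least 1.4-fold lower number from compound 3 to compound 4 (0.14 log units; that floor lies within the scatter) in this assay, so the direction seen on the first core is not contradicted, although this floor alone does not establish that direction beyond the scatter. Compound 3 stands at > 50000 nM, which is a limit of the assay and not a number, so the size of the step on this core stays unfixed and the change cannot be said to be worth the same, or a different amount, on the two cores: the same change on two cores in this assay, a 2.6-fold lower number (0.42 log units; beyond the scatter) from compound 1 to compound 2 and an at least 1.4-fold lower number (0.14 log units; that floor lies within the scatter) from compound 3 to compound 4; the limit leaves it open whether they differ With one pair on each core, this is a single comparison and not yet a rule for the series.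

The compounds shown leave open how far the step on the core of compound 3 exceeds its floor, and they include no pair that isolates the difference between the two cores. They also leave open how the series would read with a different group at the same place on the six-membered aromatic ring, such as a chloro, a methoxy or an amine, in place of the methyl or the fluoro.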